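The compounds below may be only part of what the source reports. "The series", "measured", "known", "first", "only" and "open" are said of these compounds alone.

Compound 1 `CCCCOc1ccc(C(=O)/C=C/c2c(/C=C/c3ccc(OC)cc3)cc(OC)cc2OC)cc1`, compound 2 `CCOc1ccc(C(=O)/C=C/c2c(/C=C/c3ccc(OC)cc3)cc(OC)cc2OC)cc1` and compound 3 `COc1ccc(/C=C/c2cc(OC)cc(OC)c2/C=C/C(=O)c2ccc(C(F)(F)F)cc2)cc1` share one core and differ only in the group on one aromatic carbon. In a functional assay on B16-F10 cells (Mus musculus) for antiproliferative activity, read by MTT assay, with a stated time of 48 h (on this read-out lower numbers stand for stronger inhibition and higher numbers for weaker inhibition), compound 1 gives 5.3 ug/mL, compound 2 gives 6.4 ug/mL and compound 3 gives 4.3 ug/mL. Compound 2 stands at the highest of the three numbers, yet its nearest neighbour is reached by a 1.2-fold higher number from compound 1 to compound 2 (0.08 log units; within the scatter) and its furthest by a 1.5-fold lower number from compound 2 to compound 3 (0.17 log units; within the scatter), so nothing separates the three. Compound 4 `COc1ccc(/C=C/c2cc(OC)cc(OC)c2/C=C/C(=O)c2ccc(OC)cc2)cc1` differs from compound 2 by hydrogen in place of methyl on a saturated chain carbon bound to an oxygen on an aromatic ring. The step that bears on this is the earlier shortening of the same alkoxy chain, a 1.2-fold higher number from compound 1 to compound 2 (0.08 log units; within the scatter), which stayed within the scatter; a 1.2-fold lower number from compound 1 to compound 3 (0.09 log units; within the scatter) was equally flat. Compound 4 is therefore expected at 6.5 ug/mL (range 3.8 ug/mL to 11 ug/mL), an expected step of a 1.0-fold higher number from compound 2 to compound 4 (0.01 log units; within the scatter).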

Compound 4, half-maximal inhibitory concentration: 5.8 ug/mL
Compound 4: middle estimate off by 1.1-fold (0.05 log units), on the high side; low and high end bracket the measured number.
By their numbers in this assay, from the lowest: compounds 3, 1, 4 and 2 (each within the scatter of the next).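

In this assay, the alkoxy group on this aromatic carbon can be shortened to methoxy without a readable change (a 1.1-fold lower number from compound 2 to compound 4 (0.04 log units; within the scatter)), and the same holds for the full span from butoxy (a 1.1-fold higher number from compound 1 to compound 4 (0.04 log units; within the scatter)). Methoxy and trifluoromethyl also remain indistinguishable (a 1.3-fold higher number from compound 3 to compound 4 (0.13 log units; within the scatter)), so all four groups at this position fall within the scatter of one another. No measurement bearing on this flat result is available. As far as these compounds go, whether an amine, a carboxylic acid or a hydroxyl group here would give a step beyond the scatter remains open, as does the effect of changes elsewhere on the shared core.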